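Methoxy for hydroxy on the side chain: tolerability notes

The source may report more compounds than this note shows. Statements on the series, on what has been measured and on what is new or still open speak of the compounds shown alone.

Compound 1 `C=CC(C)(C)c1[nH]c2ccc(C[C@H](O)C(C)(C)O)cc2c1/C=C1\NC(=O)[C@H](C)NC1=O`, compound 2 `C=CC(C)(C)c1[nH]c2ccc(C[C@H](O)C(C)(C)OC)cc2c1/C=C1\NC(=O)[C@H](C)NC1=O` and compound 3 `C=CC(C)(C)c1[nH]c2ccc(C[C@H](O)C(C)(C)O)cc2c1/C=c1\[nH]c(=O)c(=C)[nH]c1=O` share one core and differ at two places, the terminal oxygen of the side chain and the group on the aromatic carbon. In an ADME assay on MDCK cells (Canis lupus familiaris) for cytotoxicity, read by CellTiter-Glo, with a stated time of 40 h (a higher number here means that more compound is tolerated, a lower number that less compound is tolerated), compound 1 gives > 200000 nM, which is a limit of the assay and not a number. Compound 2 likewise gives > 200000 nM in this assay, again only a limit. Compound 3 gives > 200000 nM in this assay, a limit as well. The step that the two limits leave unreadable from compound 1 to compound 2 and the step that the two limits leave unreadable from compound 1 to compound 3 are both unreadable because the limit of > 200000 nM in this assay, at which 3 of the 3 values shown sit, covers every value shown.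

Compound 4 `C=CC(C)(C)c1[nH]c2ccc(C[C@H](O)C(C)(C)OC)cc2c1/C=c1\[nH]c(=O)c(=C)[nH]c1=O` is not yet measured. Against compound 3 the change is methyl in place of hydrogen on an oxygen on a saturated carbon. The same change, made on compound 1, gave the step that the two limits leave unreadable from compound 1 to compound 2, which says nothing about size. No step beyond the scatter is expected in this assay, so the step of a number no higher from compound 3 to compound 4 (the limit leaves the size open) is the estimate. Compound 4 is therefore expected to give about 200000 nM, within 100000 nM to 400000 nM, most likely reported once more as a limit.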

Compound 4, half-maximal cytotoxic concentration: > 200000 nM
Compound 4: no number, only a limit; the forecaster's own chance of this, stated with the estimate: 85%; the middle value lies on the limit itself.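

No step can be read from compound 3 to compound 4 or from compound 2 to compound 4 in this assay, for one reason: the limit of > 200000 nM in this assay, at which 4 of the 4 values shown sit.

The compounds shown leave open whether hydroxy to methoxy, or the change of group on the aromatic carbon, has any effect on tolerability in this assay.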